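The source may report more compounds than this note shows. Statements on the series, on what has been measured and on what is new or still open speak of the compounds shown alone.

Three compounds have been measured in a functional assay on SMMC-7721 cells (Homo sapiens) for inhibition, read by MTT assay, with a stated time of 72 h, tested at 25 uM; on this read-out higher numbers stand for more inhibition at the one concentration tested (going by the name of the read-out) and lower numbers for less inhibition:

compound 1, `CCc1nn(C)c(CO/N=C/c2c(C)nn(C)c2Oc2ccccc2C)c1Cl`, gives < 80%, which is a limit of the assay.
compound 2, `CCc1nn(C)c(CO/N=C/c2c(C)nn(C)c2Oc2ccccc2OC)c1Cl`, gives < 80%, again a limit of the assay.
compound 3, `Cc1ccc(Oc2c(/C=N\OCc3c(Cl)c(-c4ccc(Cl)cc4)nn3C)c(C)nn2C)cc1`, gives 80%.

Compound 4, `COc1ccc(Oc2c(/C=N\OCc3c(Cl)c(-c4ccc(Cl)cc4)nn3C)c(C)nn2C)cc1`, has not yet been measured in this assay.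

Compound 1 and compound 2 differ by methoxy in place of methyl on an aromatic carbon. The step that the two limits leave unreadable from compound 1 to compound 2 cannot be read, since both values are limits; this is the evidence of the limit of < 80% in this assay, at which 2 of the 3 values shown sit, at which two of the three values sit. Compound 3 and compound 4 differ by methoxy in place of methyl on an aromatic carbon. This is the same kind of change as that from compound 1 to compound 2, but not the same: in compound 2 the methoxy is ortho to a large group, in compound 4 it is para to a large group. How the core of compound 1 differs from the core of compound 3 is not broken down here.

Going by the values given here, compound 3 is the only compound with a number rather than a limit. Among the compounds with values here, the one earlier instance of this kind of change gives no readable size, so the expectation for compound 4 rests on compound 3 alone. For compound 4 the step of a number 5 percentage points lower from compound 3 to compound 4 (within the scatter) is expected to stay within the usual scatter, since the earlier step that the two limits leave unreadable from compound 1 to compound 2 gives nothing that argues for a large change. Compound 4 is therefore estimated at 75%, between 55% and 88%.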

Compound 4, a percentage reported as inhibition, at one concentration (the size of the read-out at that concentration, not a potency): 80%
Compound 4: the middle estimate sits 5 percentage points below what was measured; low and high end bracket the measured number.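

On the core of compound 3, methoxy in place of methyl, which turns 4-methylphenoxy into 4-methoxyphenoxy, gives no change at the digits printed from compound 3 to compound 4 (within the scatter) in this assay, so on this core the swap leaves the read-out where it was at the one concentration tested. The same kind of change on the core of compound 1 cannot be read, since the values of compound 1 and compound 2 are both limits of the assay and not numbers: the limit of < 80% in this assay, at which 2 of the 4 values shown sit. With one readable step and one unreadable step, the data show neither that the change behaves alike on the two cores nor that it behaves differently, and the change does not sit at the same place on the ring in the two pairs, so nothing can yet be said about carrying it across.

What the compounds shown leave open is whether the result for 4-methoxyphenoxy holds for other groups at this place, such as an amine, a carboxylic acid or a longer chain like butoxy. They also leave open how compound 3 and compound 4 would compare across a range of concentrations, since a single percentage at one concentration is not a potency.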